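Carbonyl substituent changes: compound 3 to compound 4

A few compounds are considered here, and "the series" means these few. Any claim that something is new, unique, unknown or untested is made for them only; others in the source may bear on it.

In a functional assay on NCI-H1975 cells (Homo sapiens) for antiproliferative activity (on this read-out lower numbers stand for stronger inhibition and higher numbers for weaker inhibition), compound 1 `CC(=O)N1CCc2c(C)c3c(n2-c2ccc(C(N)=O)c(c2)N[C@@H](C)[C@H](C)C1)CC(C)(C)CC3=O` gives 15 nM, compound 2 `CC[C@H](N)C(=O)N1CCc2c(C)c3c(n2-c2ccc(C(N)=O)c(c2)N[C@@H](C)[C@H](C)C1)CC(C)(C)CC3=O` gives 41 nM and compound 3 `Cc1c2c(n3c1CCN(C(=O)C1(N)CC1)C[C@@H](C)[C@H](C)Nc1cc-3ccc1C(N)=O)CC(C)(C)CC2=O` gives 72 nM. Compound 3 is separated from compound 2 only by a 1.8-fold higher number from compound 2 to compound 3 (0.24 log units; within the scatter), but stands clear of compound 1, with a 4.8-fold higher number from compound 1 to compound 3 (0.68 log units; beyond the scatter).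

Compound 4 `Cc1c2c(n3c1CCN(C(=O)[C@H](C)O)C[C@@H](C)[C@H](C)Nc1cc-3ccc1C(N)=O)CC(C)(C)CC2=O` follows from 1-hydroxyethyl in place of 1-aminocyclopropyl on a carbonyl carbon. The closest evidence is the modest 4.8-fold higher number from compound 1 to compound 3 (0.68 log units; beyond the scatter), together with the modest 2.7-fold higher number from compound 1 to compound 2 (0.44 log units; beyond the scatter). No hydroxy-bearing group has been measured, so this is an extrapolation. Partial return towards compound 1 is expected, a modest step estimated as a 2.3-fold lower number from compound 3 to compound 4 (0.35 log units; beyond the scatter). For compound 4 the estimated value is 32 nM, with an expected range of 13 nM to 75 nM.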

Compound 4, half-maximal inhibitory concentration: 52 nM
Compound 4: the middle estimate sits 1.6-fold (0.21 log units) below what was measured, and the stated range covers the measured number.
By their numbers in this assay, from the lowest: compound 1; then compounds 2, 4 and 3 (each within the scatter of the next).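

At the carbonyl carbon, 1-hydroxyethyl in place of an amine-bearing group gives no change beyond the scatter, with a 1.4-fold lower number from compound 3 to compound 4 (0.14 log units; within the scatter) and a 1.3-fold higher number from compound 2 to compound 4 (0.10 log units; within the scatter). The step from methyl remains beyond the scatter, at a 3.5-fold higher number from compound 1 to compound 4 (0.54 log units; beyond the scatter), so among these four compounds the loss does not depend on an amine, since the hydroxy-bearing group shows it too. Nothing available explains why these groups behave alike.

Open, on these data alone, is whether plain ethyl or a longer chain on this carbonyl carbon would stay with methyl or join the three substituted groups. As far as these compounds go, the opposite stereocentre of 1-hydroxyethyl also remains open.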